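Swapping Pyridin-4-yl for Thiophen-3-yl on a Homochromanone Scaffold

The compounds below may be only part of what the source reports. "The series", "measured", "known", "first", "only" and "open" are said of these compounds alone.

The series shares a common core, varied only in the aromatic group hanging off the exocyclic double bond. Compound 2 `O=C1/C(=C/c2ccncc2)COc2ccccc21` carries a pyridin-4-yl group there, and in an assay on BTI-TN-5B1-4 cells for inhibition of Amine oxidase [flavin-containing] A (Homo sapiens), read by fluorescence and Amplex Red, using microsomes, with a stated time of 15 min, tested at 100 uM (a lower number here means less inhibition, a higher number more inhibition at the concentration tested (going by the name of the read-out)), compound 2 is reported as "not active" (no number reported), with no number given. Compound 1 `Nc1ncc(/C=C2\COc3ccccc3C2=O)cn1`, bearing an aminopyrimidinyl group, is likewise reported in this assay as "not active" (no number reported). Only compound 3 `COc1ccc2c(c1)OC/C(=C\c1c[nH]cn1)C2=O` returns a figure: in this assay compound 3 gives 40%. Within the data shown here, compound 2 is thus one of the two compounds reported as not active, while compound 3 is the only one with a reported number.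

Compound 4 `O=C1/C(=C/c2ccsc2)COc2ccccc21` differs from compound 2 by one change: thiophen-3-yl in place of pyridin-4-yl on a double-bonded chain carbon bound to a double-bonded ring carbon. Among the measured compounds shown here, no pair of measured compounds shows this exchange, so the size of the step in this assay is unknown; a modest gain, if any, seems the most that can be expected, since compound 3 shows that a small five-membered heteroaryl can give 40% where compound 2 gives none. On this basis compound 4 is estimated at 22% in this assay, within a range from 0% to 50%.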

Compound 4, a percentage reported as inhibition, at one concentration (the size of the read-out at that concentration, not a potency): 40%
Compound 4: the middle estimate sits 18 percentage points below what was measured, and the stated range covers the measured number.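

In this assay, among these compounds, compound 2 has no number, so no step to compound 4 at 40% can be read. The compounds shown leave open how much exchanging pyridin-4-yl for thiophen-3-yl changes inhibition, and nothing available here offers an explanation of the result.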